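This account rests on a few compounds, and the source may have more. Where it says the series, first, only, none or still open, it means among the compounds named here.

In a functional assay with Homo sapiens as the target (a higher number here means a weaker inhibitor, a lower number a stronger inhibitor), three compounds that share one core and differ only in the aromatic ring on the oxygen have been measured: compound 1 (`CC(C)[C@H](NC(=O)COc1cccc2ccccc12)C(=O)N[C@@H](CC(=O)O)C(=O)COc1ccccc1C(F)(F)F`) gives 17300 nM, compound 2 (`CC(C)[C@H](NC(=O)COc1cccc2ccccc12)C(=O)N[C@@H](CC(=O)O)C(=O)COc1ccc(C#N)cc1`) gives 26700 nM and compound 3 (`CC(C)[C@H](NC(=O)COc1cccc2ccccc12)C(=O)N[C@@H](CC(=O)O)C(=O)COc1cc(F)cc(F)c1F`) gives 11200 nM. The closest comparison for the last of these is a 1.5-fold lower number from compound 1 to compound 3 (0.19 log units; within the scatter), so those two cannot be separated, whereas a 2.4-fold lower number from compound 2 to compound 3 (0.38 log units; beyond the scatter) is a modest step.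

Compound 4 (`CC(C)[C@H](NC(=O)COc1cccc2ccccc12)C(=O)N[C@@H](CC(=O)O)C(=O)COc1c(F)c(F)cc(F)c1F`) differs from compound 3 by one substitution: fluoro in place of hydrogen on an aromatic carbon. This turns 2,3,5-trifluorophenyl into 2,3,5,6-tetrafluorophenyl. For the measured compounds named here, no measured step adds a single fluoro, so the evidence is indirect. Exchanging the whole ring gave only a 1.5-fold higher number from compound 1 to compound 2 (0.19 log units; within the scatter) and, at most, the modest step above. A smaller edit is therefore not expected to do much in this assay. The expected change is a 1.2-fold lower number from compound 3 to compound 4 (0.07 log units; within the scatter), which is no step beyond the scatter. Compound 4 is estimated at 9500 nM, with an expected range of 4500 nM to 20000 nM.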

Compound 4, half-maximal inhibitory concentration: 6250 nM
Compound 4: the middle estimate sits 1.5-fold (0.18 log units) above what was measured; the range from low to high includes it.
By their numbers in this assay, from the lowest: compounds 4, 3, 1 and 2 (each within the scatter of the next, the first and the last beyond it).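

In this assay, for the compounds shown here, this is the first single added fluoro at this position, and it gives a 1.8-fold lower number from compound 3 to compound 4 (0.25 log units; within the scatter), so 2,3,5-trifluorophenyl and 2,3,5,6-tetrafluorophenyl cannot be told apart here. The tetrafluorinated ring nevertheless separates from both other rings, with a 4.3-fold lower number from compound 2 to compound 4 (0.63 log units; beyond the scatter) against 4-cyanophenyl and a 2.8-fold lower number from compound 1 to compound 4 (0.44 log units; beyond the scatter) against 2-(trifluoromethyl)phenyl, whereas 2,3,5-trifluorophenyl stood apart only from 4-cyanophenyl. Nothing available bears on why the numbers fall this way.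

The compounds shown leave open whether a fifth fluoro, giving pentafluorophenyl, would move the number beyond the scatter from compound 4. They also leave open how this ring position responds to a methoxy group or an amine in place of fluoro.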